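Replacing Chloro with Ethoxy: an Expected Recovery of Potency

A few compounds are considered here, and "the series" means these few. Any claim that something is new, unique, unknown or untested is made for them only; others in the source may bear on it.

Compound 1, `COc1cc(-n2ncnc2-c2ccc(OC(C)C)cc2)cc(OC)c1OC`, gives 650 nM in a functional assay on Jurkat cells (Homo sapiens) for antiproliferative activity, read by MTT assay, with a stated time of 72 h; on this read-out lower numbers stand for stronger inhibition and higher numbers for weaker inhibition.
Compound 2, `COc1ccc(-c2ncnn2-c2cc(OC)c(OC)c(OC)c2)cc1`, gives 50 nM.
Compound 3, `COc1cc(-n2ncnc2-c2ccc(Cl)cc2)cc(OC)c1OC`, gives only a limit of the assay, > 10000 nM, not a number.

Compound 3 therefore stands at the weak end of the three, at the limit of > 10000 nM in this assay, at which 1 of the 3 values shown sits. Compound 4, `CCOc1ccc(-c2ncnn2-c2cc(OC)c(OC)c(OC)c2)cc1`, differs from compound 3 by ethoxy in place of chloro on an aromatic carbon. For the measured compounds named here, two measured steps bear on this: an at least 200-fold higher number from compound 2 to compound 3 (2.30 log units; beyond the scatter) and an at least 15-fold higher number from compound 1 to compound 3 (1.18 log units; beyond the scatter), both large losses when chloro took the place of an alkoxy group. Reversing that direction, with ethoxy in place of chloro, should give a large fall in the number. Compound 2 with methoxy gives 50 nM and compound 1 with isopropoxy gives 650 nM, so an ethoxy is expected to land between them. Compound 4 is estimated at 150 nM, within 50 nM to 600 nM. The expected step is an at least 66-fold lower number from compound 3 to compound 4 (1.82 log units; beyond the scatter).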

Compound 4, half-maximal inhibitory concentration: 5 nM
For compound 4 the middle estimate is 30-fold (1.48 log units) above the measured one; measured number below the stated range.
By their numbers in this assay, from the lowest: compound 4; then compound 2; then compound 1. At a limit, above all of these: compound 3.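

From methoxy to ethoxy to isopropoxy, the number does not move in one direction: the change gives a 10-fold lower number from compound 2 to compound 4 (1.00 log units; beyond the scatter) and a 130-fold lower number from compound 1 to compound 4 (2.11 log units; beyond the scatter). Ethoxy in place of chloro gives an at least 2000-fold lower number from compound 3 to compound 4 (3.30 log units; beyond the scatter). Compound 3 stands at a limit of the assay, not at a number: the limit of > 10000 nM in this assay, at which 1 of the 4 values shown sits.

The compounds shown leave open how narrow this preference is, since a straight propoxy chain or a longer butoxy chain could fall on either side of ethoxy. They also leave open whether an amine in place of the ethoxy would keep the low number.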